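A few compounds are considered here, and "the series" means these few. Any claim that something is new, unique, unknown or untested is made for them only; others in the source may bear on it.

In a functional assay on U-87MG ATCC cells (Homo sapiens) for cytotoxicity, read by MTT assay, with a stated time of 72 h (on this read-out lower numbers stand for stronger inhibition and higher numbers for weaker inhibition), compound 1 `CN(C)CCn1cnnc1-c1cc(Oc2ccc(NC(=O)N/N=C/c3ccc(Cl)cc3Cl)cc2F)ccn1` gives 2330 nM, the second highest of the three numbers in hand. Compound 3 `CN(C)CCn1cnnc1-c1cc(Oc2ccc(NC(=O)N/N=C/c3ccc(F)cc3F)cc2F)ccn1` gives 1900 nM, and compound 2 `CN(C)CCn1cnnc1-c1cc(Oc2ccc(NC(=O)N/N=C/c3ccccc3O[N+](=O)[O-])cc2F)ccn1` gives 7150 nM. Both differ from compound 1 only in the aryl group on the carbon with a double bond to nitrogen: a 1.2-fold lower number from compound 1 to compound 3 (0.09 log units; within the scatter), whereas a 3.1-fold higher number from compound 1 to compound 2 (0.49 log units; beyond the scatter). Compound 4 `CN(C)CCn1cnnc1-c1cc(Oc2ccc(NC(=O)N/N=C/c3cc(Br)c(O)c(Br)c3)cc2F)ccn1` alters the same place: 3,5-dibromo-4-hydroxyphenyl in place of 2,4-dichlorophenyl on a carbon with a double bond to nitrogen. The two measured steps at this position ranged from no change beyond the scatter to a modest weakening, so for compound 4 a small to modest rise in the number, a 1.5-fold higher number from compound 1 to compound 4 (0.18 log units; within the scatter), is expected in this assay. Compound 4 is therefore estimated at 3500 nM, within a range of 1400 nM to 9000 nM.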

Compound 4, half-maximal inhibitory concentration: > 100000 nM
Compound 4: no number, only a limit (the forecaster's own chance of this, stated with the estimate: 5%); at least 28-fold (1.45 log units) between middle value and limit.
By their numbers in this assay, from the lowest: compounds 3 and 1 (each within the scatter of the next); then compound 2. At a limit, above all of these: compound 4.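

In this assay compound 4 gives no number, only a limit: the limit of > 100000 nM in this assay, at which 1 of the 4 values shown sits. The steps read an at least 42-fold higher number from compound 1 to compound 4 (1.63 log units; beyond the scatter), an at least 52-fold higher number from compound 3 to compound 4 (1.72 log units; beyond the scatter) and an at least 13-fold higher number from compound 2 to compound 4 (1.14 log units; beyond the scatter). The aryl group on a carbon with a double bond to nitrogen can therefore carry a large change, not only the modest ones seen earlier, and 3,5-dibromo-4-hydroxyphenyl stands apart from all three earlier groups. On these data alone, whether a phenyl group bearing hydroxyl alone, or bromine alone, gives the same rise remains open. So does the effect of an amine in place of that hydroxyl.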